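The source may hold more compounds than are shown below. What is called first, only, known or untested is meant among the compounds shown, and "the series" means these compounds.

Measured so far in a functional assay on MDA-MB-231 cells (Homo sapiens) for antiproliferative activity, read by MTT assay, with a stated time of 24 h; a higher number here means a weaker inhibitor, a lower number a stronger inhibitor:
- Compound 1 `O=C(NNc1ccccc1Cl)c1ccccc1NS(=O)(=O)c1cnc(O)nc1O`: 18900 nM
- Compound 2 `Cc1ccc(C(=O)NNC(=O)c2ccccc2NS(=O)(=O)c2cnc(O)nc2O)cc1`: > 20000 nM

Compound 2 gives > 20000 nM, which is a limit and not a number. Going by the values given here, compound 1 is the only compound with a measured number here, and (the limit of > 20000 nM in this assay, at which 1 of the 2 values shown sits).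

Compound 3 `O=C(NNC(=O)c1ccccc1NS(=O)(=O)c1cnc(O)nc1O)c1ccccc1Cl` has 2-chlorophenyl in place of 4-methylphenyl on a carbonyl carbon. This change itself has never been measured. The nearest evidence is a step that also involves the 2-chlorophenyl group, though on an amine nitrogen: an at least 1.0-fold higher number from compound 1 to compound 2 (0.02 log units; that floor lies within the scatter). That step lies within the scatter, so no step beyond the scatter, in either direction, is expected in this assay.

Compound 3 is therefore expected at about 20000 nM, within an estimated range of 10000 nM to 40000 nM. This estimate means an expected a number no higher from compound 2 to compound 3 (the limit leaves the size open).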

Compound 3, half-maximal inhibitory concentration: 8310 nM
Compound 3: the middle estimate sits 2.4-fold (0.38 log units) above what was measured; the whole stated range lies above it.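

The carbonyl-carbon position responds to the group it carries: in this assay, 2-chlorophenyl in place of 4-methylphenyl gives an at least 2.4-fold lower number from compound 2 to compound 3 (0.38 log units; beyond the scatter). Compound 2 has a limit and not a number, so that step has only a floor: the limit of > 20000 nM in this assay, at which 1 of the 3 values shown sits. The linking carbonyl also counts, since (2-chlorophenyl)carbonyl in place of 2-chlorophenyl on an amine nitrogen gives a 2.3-fold lower number from compound 1 to compound 3 (0.36 log units; beyond the scatter), a step beyond the scatter that the first two compounds could not show.

On these data alone, the swap from 4-methylphenyl to 2-chlorophenyl changes more than one feature of the ring, so it remains open which feature matters, and 4-chlorophenyl or 2-methylphenyl on the same carbonyl carbon could separate them. Also open, as far as these compounds go, is what a group without an aromatic ring, such as a longer carbon chain, would give there.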